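Propargyloxy in place of butoxycarbonyl: expected step

This account rests on a few compounds, and the source may have more. Where it says the series, first, only, none or still open, it means among the compounds named here.

Among the compounds with values here, in a functional assay on the whole organism with Scenedesmus acutus as the target, with a stated time of 20 h (on this read-out lower numbers stand for stronger inhibition and higher numbers for weaker inhibition), compound 1 (`CCCCOC(=O)c1cc(N2C(=O)C3=C(CCCC3)C2=O)ccc1Cl`) gives 7760 nM, the only actual number so far. Compound 2 (`CCCCCCCCOC(=O)c1cc(N2C(=O)C3=C(CCCC3)C2=O)ccc1Cl`) gives > 100000 nM, which is a limit of the assay and not a number.

Next is compound 3 (`C#CCOc1cc(N2C(=O)C3=C(CCCC3)C2=O)ccc1Cl`), with the change propargyloxy in place of butoxycarbonyl on an aromatic carbon, ortho to a chloro group. Within the data shown here, one measured step bears on it, and only indirectly: an at least 12-fold higher number from compound 1 to compound 2 (1.11 log units; beyond the scatter). That large step lengthens the chain of the ester, whereas compound 3 loses the ester altogether. Since the larger group of compound 2 went with the step of an at least 12-fold higher number from compound 1 to compound 2 (1.11 log units; beyond the scatter), the smaller propargyloxy group is expected to give a lower number in this assay, with wide uncertainty. The expected step is a 7.8-fold lower number from compound 1 to compound 3 (0.89 log units; beyond the scatter). Compound 3 is estimated at 1000 nM, within an expected range of 60 nM to 15000 nM.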

Compound 3, half-maximal inhibitory concentration: 537 nM
The estimate for compound 3 lay 1.9-fold (0.27 log units) above the measured number; the range from low to high includes it.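

In this assay, propargyloxy in place of butoxycarbonyl on this aromatic carbon gives a 14-fold lower number from compound 1 to compound 3 (1.16 log units; beyond the scatter), so the butoxycarbonyl group is not required for inhibition at this position. The earlier pair varied only the chain of the ester, whereas this change removes the ester altogether and still gives a measured number. Compound 2 remains a limit and not a number: the limit of > 100000 nM in this assay, at which 1 of the 3 values shown sits.

The change from compound 1 to compound 3 replaces the ester with an ether link, shortens the chain and brings in a triple bond all at once, and the compounds shown do not separate these parts. A propoxy group or a propargyl ester on the same aromatic carbon would show whether the triple bond or the loss of the ester goes with the step.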